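The source may hold more compounds than are shown below. What is called first, only, known or untested is meant among the compounds shown, and "the series" means these compounds.

Measured so far:
compound 1, `O=C1NC(=O)/C(=C/C2=Cc3ccccc3OC2)S1`, 99400 nM;
compound 2, `CN1C(=N)NC(=O)/C1=C/C1=Cc2ccccc2OC1`, 149000 nM.

Both numbers come from a functional assay on MCF7 cells (Homo sapiens) for antiproliferative activity, read by MTT assay, with a stated time of 72 h; a lower number here means a stronger inhibitor, a higher number a weaker inhibitor. Compound 1 and compound 2 give values that sit within the scatter of each other, so nothing separates them; both are weak. Compound 3, `CCN1C(=O)S/C(=C\C2=Cc3ccccc3OC2)C1=O`, is not yet measured. It differs from compound 1 in one place: ethyl in place of hydrogen on an amide-type nitrogen in a ring. For the measured compounds named here, no measured pair shows what such a change does here, so the step from compound 1 to compound 3 is expected to be small, with no clear direction beyond the scatter, as a 1.3-fold higher number from compound 1 to compound 3 (0.12 log units; within the scatter) in this assay . Compound 3 is therefore estimated at 130000 nM, within 45000 nM to 400000 nM.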

Compound 3, half-maximal inhibitory concentration: > 200000 nM
Compound 3: only a limit was reported; the forecaster's own chance of this, stated with the estimate: 35%; middle value at least 1.5-fold (0.18 log units) from the limit.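

Replacing the hydrogen on the amide-type nitrogen in the ring with ethyl gives, in this assay, an at least 2.0-fold higher number from compound 1 to compound 3 (0.30 log units; that floor lies within the scatter). For the compounds shown here, this is the first reading at this position, and it shows no gain in strength from filling it with ethyl. The value for compound 3 is a limit and not a number: the limit of > 200000 nM in this assay, at which 1 of the 3 values shown sits.

From the compounds shown here alone, the true size of the step remains unknown, since its floor does not clear the scatter. Going by these compounds, whether a longer chain, or a chain ending in an amine or a carboxylic acid, would behave differently on this nitrogen remains open.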